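Diethylamino side chain after two inactive limits

The source may report more compounds than this note shows. Statements on the series, on what has been measured and on what is new or still open speak of the compounds shown alone.

compound 1 `CCn1c(N)c(-c2nc3ccccc3[nH]2)c2nc(C#N)c(C#N)nc21`: > 50000 nM (a limit)
compound 2 `N#Cc1nc2c(-c3nc4ccccc4[nH]3)c(N)n(CCO)c2nc1C#N`: > 50000 nM (a limit)
compound 3 `CCN(CC)CCCn1c(N)c(-c2nc3ccccc3[nH]2)c2nc(C#N)c(C#N)nc21`: not yet measured

In a functional assay on HeLa cells (Homo sapiens) for antiproliferative activity, read by MTT assay, with a stated time of 48 h (on this read-out lower numbers stand for stronger inhibition and higher numbers for weaker inhibition), compound 2 gives > 50000 nM, which is a limit and not a number. Going by the values given here, the series so far shows only (the limit of > 50000 nM in this assay, at which 2 of the 2 values shown sit). Among the compounds with values here, the one measured step is a step that the two limits leave unreadable from compound 1 to compound 2, so it offers no size to carry forward.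

Compound 3 carries (diethylamino)methyl in place of the hydroxy of compound 2, on a saturated chain carbon, two bonds along the chain from an aromatic nitrogen: (diethylamino)methyl in place of hydroxy on a saturated chain carbon, two bonds along the chain from an aromatic nitrogen. Cut one bond further out, this reads 2-hydroxyethyl to 3-(diethylamino)propyl.

With no readable step to go on, the expectation is weak. The expected step is an at least 1.6-fold lower number from compound 2 to compound 3 (0.22 log units; that floor lies within the scatter), an estimate leaning slightly toward stronger inhibition. The estimate for compound 3 is 30000 nM, with an expected range of 6000 nM to 50000 nM.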

Compound 3, half-maximal inhibitory concentration: 3150 nM
Estimate against measurement, compound 3: 9.5-fold (0.98 log units) above, and the stated range ends above it.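

In this assay, going by these compounds alone, the 3-(diethylamino)propyl chain gives the first readable change at this position: an at least 15-fold lower number from compound 2 to compound 3 (1.20 log units; beyond the scatter). Measured against the shorter chain without a hydroxy, the change is likewise an at least 15-fold lower number from compound 1 to compound 3 (1.20 log units; beyond the scatter). Both steps start from a limit, the step between the two earlier compounds cannot be read, and compound 3 is the only one of the three with a number, the others remaining at: the limit of > 50000 nM in this assay, at which 2 of the 3 values shown sit.

The compounds shown do not separate the contribution of the amine nitrogen from that of the longer chain, a question that a plain pentyl chain would bear on. Also open, as far as these compounds go, is how far the result depends on the diethylamino group itself, as against a morpholine, a primary amine or a carboxylic acid at the chain end.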